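A few compounds are considered here, and "the series" means these few. Any claim that something is new, unique, unknown or untested is made for them only; others in the source may bear on it.

Of the compounds shown here, three have been measured so far in a functional assay on MCF7 cells (Homo sapiens) for antiproliferative activity, read by MTT assay, with a stated time of 48 h (on this read-out lower numbers stand for stronger inhibition and higher numbers for weaker inhibition), as follows.

compound 1 `COc1ccc(C2OC(c3ccc4ccccc4c3)=NN2C(C)=O)cc1` gives 7.35 ug/mL
compound 2 `CC(=O)N1N=C(c2ccc3ccccc3c2)OC1c1ccccc1Cl` gives 2.36 ug/mL
compound 3 `CC(=O)N1N=C(c2ccc3ccccc3c2)OC1c1ccc([N+](=O)[O-])cc1` gives 7.59 ug/mL

Compound 3 stands at the upper end of this small set, but not alone. The gap of a 1.0-fold higher number from compound 1 to compound 3 (0.01 log units; within the scatter) gives it no separate place from its nearest neighbour. The other gap is wider, at a 3.2-fold higher number from compound 2 to compound 3 (0.51 log units; beyond the scatter) and it is the larger of the two.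

The next compound is compound 4 `CC(=O)N1N=C(c2ccc3ccccc3c2)OC1c1ccccc1O` with 2-hydroxyphenyl in place of 4-nitrophenyl on a saturated ring carbon. Among the measured compounds shown here, no hydroxy-bearing compound has been measured, so the evidence is indirect. For the measured compounds named here, two steps bear on the change. The step of a 1.0-fold higher number from compound 1 to compound 3 (0.01 log units; within the scatter) shows that exchanging one 4-substituted phenyl for another moved nothing here. The step of a 3.1-fold lower number from compound 1 to compound 2 (0.49 log units; beyond the scatter) is modest and leads to the only 2-substituted phenyl measured so far. Going by the values given here, on that single precedent, a lower number is expected in this assay for compound 4, though a smaller drop than the one separating the 2-chlorophenyl compound from compound 3.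

The expected change is a 1.8-fold lower number from compound 3 to compound 4 (0.26 log units; within the scatter) and it may not clear the scatter. For compound 4 the estimated value is 4.2 ug/mL with an expected range from 1.7 ug/mL to 10 ug/mL in this assay.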

Compound 4, half-maximal inhibitory concentration: 2.12 ug/mL
The estimate for compound 4 lay 2.0-fold (0.30 log units) above the measured number; measured number inside the range.
By their numbers in this assay, from the lowest: compounds 4 and 2 (each within the scatter of the next); then compounds 1 and 3 (each within the scatter of the next).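

The 2-hydroxyphenyl compound now joins the 2-chlorophenyl compound in this assay, and a 1.1-fold lower number from compound 2 to compound 4 (0.05 log units; within the scatter) shows that hydroxy in place of chloro on this aromatic carbon leaves the number unchanged within the scatter. Among the compounds shown here, both 4-substituted compounds lie on the weaker side of compound 4 , with a 3.5-fold lower number from compound 1 to compound 4 (0.54 log units; beyond the scatter) and a 3.6-fold lower number from compound 3 to compound 4 (0.55 log units; beyond the scatter) as the two steps, so across these four compounds the 2-substituted phenyls separate from the 4-substituted phenyls and no compound goes against that split. Nothing measured here accounts for this separation.

Each step across the split changes the group and its place on the phenyl together, so the compounds shown do not tell the effect of place from that of the group, as no pair carries one group at two places on the phenyl. On these data alone, it also remains open whether an amine or a carboxylic acid in place of hydroxy on that aromatic carbon would stay with compound 2 and compound 4 or fall with compound 1 and compound 3 .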